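The source may hold more compounds than are shown below. What is called first, only, known or untested is meant among the compounds shown, and "the series" means these compounds.

Compound 1 `CC(C)N(Cc1cccc(OCCCCCC(=O)O)c1)C(=O)c1ccc(-c2cccc(Oc3ccccc3)c2)cc1` was examined in an ADME assay on HepG2 cells (Homo sapiens) for cytotoxicity, read by CellTiter-Glo and resazurin assay, with a stated time of 72 h; a higher number here means that more compound is needed for the effect, a lower number that less compound is needed. In this assay compound 1 reaches only a limit of the assay, > 18700 nM. Compound 2 `CC(C)N(Cc1cccc(OCCCCCC(=O)O)c1)C(=O)c1ccc(-c2cccc(OCc3ccccc3)c2)cc1` carries benzyl in place of phenyl on an oxygen on an aromatic ring on the core of compound 1. In this assay compound 2 likewise stops at a limit, > 26000 nM. The step that the two limits leave unreadable from compound 1 to compound 2 therefore cannot be sized. Compound 3 `CCOC(=O)CCCCCOc1cccc(CN(C(=O)c2ccc(-c3cccc(Oc4ccccc4)c3)cc2)C(C)C)c1` differs from compound 1 by ethyl in place of hydrogen on an oxygen next to a carbonyl group. In this assay compound 3 also gives only a limit, > 26000 nM, so a step that the two limits leave unreadable from compound 1 to compound 3 stays unreadable as well. Compound 4 `CCOC(=O)CCCCCOc1cccc(CN(C(=O)c2ccc(-c3cccc(OCc4ccccc4)c3)cc2)C(C)C)c1` has not yet been measured; it differs from compound 3 by benzyl in place of phenyl on an oxygen on an aromatic ring, the same change that leads from compound 1 to compound 2, made here on the core of compound 3. Compound 4 is expected to give roughly 30000 nM, between 18000 nM and 100000 nM, most likely once more as a limit. That expected step that the limit leaves unreadable from compound 3 to compound 4 rests on the fact that two of the three known values sit at the limit of > 26000 nM in this assay, at which 2 of the 3 values shown sit, and the third at the limit of > 18700 nM in this assay, at which 1 of the 3 values shown sits.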

Compound 4, half-maximal effective concentration: > 26000 nM
Compound 4: only a limit was reported; the forecaster's own chance of this, stated with the estimate: 85%; the middle value does not contradict the limit.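

Compound 2, compound 3 and compound 4 all give only limits, so neither step leading to compound 4 can be read. The compounds shown leave open where any of them would reach half-maximal effect in this assay, and whether either change shifts it.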